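This account rests on a few compounds, and the source may have more. Where it says the series, first, only, none or still open, it means among the compounds named here.

Measured so far:
Compound 1 `Cc1c(C2CCCC2)c(=O)on1C(=O)N1CCCCC1`: 6 nM
Compound 2 `Cc1c(C(C)C)c(=O)on1C(=O)NC(C)(C)C`: > 1000 nM
Compound 3 `Cc1c(C(C)C)c(=O)on1C(=O)N(C)Cc1ccco1`: 4 nM

All three share a core and differ in the group attached to the carbonyl on the ring nitrogen. In an assay (strain Wistar) for inhibition of Hormone-sensitive lipase (Rattus norvegicus), read by spectrophotometry (on this read-out higher numbers stand for weaker inhibition and lower numbers for stronger inhibition), compound 1 gives 6 nM. Compound 2, in this assay, gives only a limit, > 1000 nM, so no number is known for it. Compound 3 gives 4 nM in this assay, and this sits within the usual scatter of the value of compound 1, so the two cannot be told apart by these numbers. Where the limit is concerned, the limit of > 1000 nM in this assay, at which 1 of the 3 values shown sits, marks how compound 2 differs from the other two.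

Compound 4 `Cc1c(C(C)C)c(=O)on1C(=O)N(C)c1ccc(Cl)cc1` has not yet been measured. It differs from compound 3 in one place: 4-chlorophenyl in place of (furan-2-yl)methyl on an amide-type nitrogen. Among the measured compounds shown here, no measured pair shows this kind of change, so the size of the step can only be guessed. The two potent compounds carry differing groups on that nitrogen, and a modest weakening is expected for compound 4 in this assay, an estimated step of a 3.8-fold higher number from compound 3 to compound 4 (0.57 log units; beyond the scatter). Compound 4 is thus expected to give about 15 nM in this assay, within a range from 3 nM to 100 nM.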

Compound 4, half-maximal inhibitory concentration: 17 nM
Compound 4: middle estimate off by 1.1-fold (0.05 log units), on the low side; the measured number falls inside the stated range.
By their numbers in this assay, from the lowest: compounds 3 and 1 (each within the scatter of the next); then compound 4. At a limit, above all of these: compound 2.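

With compound 4, this position gains its first direct comparison: in this assay, 4-chlorophenyl in place of (furan-2-yl)methyl on the amide-type nitrogen gives a 4.3-fold higher number from compound 3 to compound 4 (0.63 log units; beyond the scatter) and the step is modest. The change swaps a five-membered aromatic ring with one hetero atom for a six-membered aromatic ring of carbon only, and compound 4 still gives 17 nM in this assay, so this nitrogen can carry either group and inhibition remains strong on this read-out. These numbers cannot separate the contributions of the ring, the chlorine and the loss of the furan oxygen, and nothing available bears on the cause of the step.

The compounds shown leave open whether the chlorine matters, as a plain phenyl group on this nitrogen would be the direct comparison for compound 4, and whether a benzyl group would behave more like (furan-2-yl)methyl or like 4-chlorophenyl. Also open, as far as these compounds go, is how an amine or a carboxylic acid placed on that aromatic ring would change the number in this assay.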